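Replacing the 2-methoxyphenyl Group of Compound 2

The compounds below may be only part of what the source reports. "The series", "measured", "known", "first", "only" and "open" are said of these compounds alone.

Antiproliferative compounds can be compared in a functional assay on HT-29 cells (Homo sapiens) for antiproliferative activity, read by sulforhodamine B assay, with a stated time of 48 h; on this read-out higher numbers stand for weaker inhibition and lower numbers for stronger inhibition. In this test, compound 1 `CN1CCN(c2ccc(S(=O)(=O)Oc3cc(Cl)c(Cl)cc3Cl)cc2)C1=O` gives 600 nM. On these data alone, compound 2 `CCCN1CCN(c2ccc(S(=O)(=O)Oc3ccccc3OC)cc2)C1=O` reads > 100000 nM, and this is a limit of the assay and not a number. the limit of > 100000 nM in this assay, at which 1 of the 2 values shown sits, is therefore all that can be said of its position, so its true value remains unknown.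

Compound 3 `CCCN1CCN(c2ccc(S(=O)(=O)Oc3cc(Cl)c(Cl)cc3Cl)cc2)C1=O` is made from compound 2 by one change: 2,4,5-trichlorophenyl in place of 2-methoxyphenyl on an oxygen. Compound 1 also carries the 2,4,5-trichlorophenyl group and gives 600 nM, which is the basis for expecting a large move towards stronger inhibition. The expected size of this move is an at least 160-fold lower number from compound 2 to compound 3 (2.22 log units; beyond the scatter). Compound 3 is estimated to give about 600 nM, with an expected range from 150 nM to 3000 nM.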

Compound 3, half-maximal inhibitory concentration: 19000 nM
The estimate for compound 3 lay 32-fold (1.50 log units) below the measured number, outside the stated range (above it).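

Exchanging 2-methoxyphenyl for 2,4,5-trichlorophenyl on the oxygen bound to the sulfonyl sulfur moves the result in this assay towards stronger inhibition, with an at least 5.2-fold lower number from compound 2 to compound 3 (0.72 log units; beyond the scatter) as the step. That step is only a minimum, since one end of it is a limit and not a number: the limit of > 100000 nM in this assay, at which 1 of the 3 values shown sits. With the 2,4,5-trichlorophenyl group held constant, ethyl in place of hydrogen on the saturated chain carbon bound to the amide-type nitrogen in the ring gives a 32-fold higher number from compound 1 to compound 3 (1.50 log units; beyond the scatter) as its step, so the group on the oxygen does not set the result alone.

On these data alone, it remains open whether a still longer chain, such as butyl, or a chain ending in an amine would weaken inhibition further. Also open, as far as these compounds go, is how a single chlorine on the phenyl group would compare with the three in 2,4,5-trichlorophenyl.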